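Ethoxycarbonyl for 4-ethylcyclohexyl: how much will cells tolerate?

A few compounds are considered here, and "the series" means these few. Any claim that something is new, unique, unknown or untested is made for them only; others in the source may bear on it.

Compound 1 `CC[C@H]1CC[C@H](c2ccc(NC(=S)Nc3cccc(C(F)(F)F)c3)cc2)CC1` gives 10000 nM in an ADME assay on BHK cells (Mesocricetus auratus) for cytotoxicity, read by MTT assay, with a stated time of 96 h; a lower number here means that less compound is tolerated, a higher number that more compound is tolerated
Compound 2 `COc1cccc(NC(=S)Nc2cccc(C(F)(F)F)c2)c1` gives 12000 nM in this assay

These two numbers are all that has been measured so far. Compound 1 at 10000 nM and compound 2 at 12000 nM lie within the usual scatter of repeated measurements, so the two cannot be ranked, and compound 1 stands level with its only comparator.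

Compound 3 `CCOC(=O)c1ccc(NC(=S)Nc2cccc(C(F)(F)F)c2)cc1` has not yet been tested. It keeps the core of compound 1. The change ethoxycarbonyl in place of 4-ethylcyclohexyl on an aromatic carbon puts ethoxycarbonyl in place of 4-ethylcyclohexyl on an aromatic carbon, para to a large group.

Within the data shown here, no two measured compounds differ in one place only, so no earlier step shows what such a swap does in this assay here. Among the measured compounds shown here, the only guide is how closely the measured numbers sit, with compound 2 at 12000 nM near compound 1, and so no step beyond the scatter is expected. The estimated step of a 1.1-fold higher number from compound 1 to compound 3 (0.04 log units; within the scatter) stays within that scatter. Compound 3 is estimated at 11000 nM with an expected range of 4500 nM to 27000 nM in this test.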

Compound 3, half-maximal cytotoxic concentration: 50000 nM
Compound 3: middle estimate off by 4.5-fold (0.66 log units), on the low side, and the stated range ends below it.
By their numbers in this assay, from the lowest: compounds 1 and 2 (each within the scatter of the next); then compound 3.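

Among these compounds, the change of 4-ethylcyclohexyl to ethoxycarbonyl on this aromatic carbon, para to a large group, gives a 5.0-fold higher number from compound 1 to compound 3 (0.70 log units; beyond the scatter) in this assay, so the group at this position can alter how much compound the cells tolerate, which the earlier compounds, with no single-place comparison between them, could not show. The change is not a single alteration, however: a carbon-only ring with two defined stereocentres leaves, and a group with no ring, fewer heavy atoms and two hydrogen-bond acceptors enters, and one step cannot separate these differences. No measurement shown here accounts for the step.

On these data alone, it remains open whether the higher number follows from losing the 4-ethylcyclohexyl group or from gaining ethoxycarbonyl, a question that a plain ethyl group, a cyclohexyl ring without the ethyl chain, or a carboxylic acid on the same aromatic carbon could help to settle. As far as these compounds go, it is also open whether the same swap would give a similar step if the rest of the core of compound 1 were changed.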